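Hydroxy replaces cyclopropylamino on a carbonyl carbon

The source may report more compounds than this note shows. Statements on the series, on what has been measured and on what is new or still open speak of the compounds shown alone.

In an ADME assay on MRC5 cells (Homo sapiens) for inhibition, with a stated time of 72 h (on this read-out lower numbers stand for an effect already at smaller amounts and higher numbers for an effect only at larger amounts of compound), compound 1 (`COc1cccc(OC)c1C(=O)Nc1c[nH]nc1C(=O)NC1CC1`) gives > 50000 nM as its reading, and this is a limit of the assay and not a number. It therefore stands at the limit of > 50000 nM in this assay, at which 1 of the 2 values shown sits. Among the compounds with values here, compound 2 (`CO[C@H]1CC[C@H](NC(=O)c2n[nH]cc2NC(=O)c2ccc(OC(F)F)cc2)CC1`) gives 2500 nM in this assay as a true number, but it has no measured step to compound 1.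

Compound 3 (`COc1cccc(OC)c1C(=O)Nc1c[nH]nc1C(=O)O`) is still unmeasured. It carries hydroxy in place of cyclopropylamino on a carbonyl carbon, so cyclopropylcarbamoyl becomes carboxy. Within the data shown here, no measured pair shows this change. The expectation thus rests on the change itself and on compound 1 with its limit of > 50000 nM in this assay as the only anchor.

Nothing in these data suggests that an effect will appear at smaller amounts, so no step beyond the usual scatter is expected. The expected change is a number no higher from compound 1 to compound 3 (the limit leaves the size open) in this assay and no larger. For compound 3 the estimate is 50000 nM with an expected range from 20000 nM to 100000 nM in this assay and the assay may well report only a limit.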

Compound 3, half-maximal effective concentration: > 50000 nM
Compound 3 ended at the assay's limit; the forecaster's own chance of this, stated with the estimate: 80%; the middle value lies on the limit itself.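

In this assay compound 3 gives > 50000 nM, which is a limit and not a number. Compound 1 also stands at a limit, and no step can be read between compound 1 and compound 3. The compounds shown leave open whether hydroxy in place of cyclopropylamino on a carbonyl carbon changes this read-out at all: the limit of > 50000 nM in this assay, at which 2 of the 3 values shown sit.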